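One Added Methyl on a Peptide Chain

This account rests on a few compounds, and the source may have more. Where it says the series, first, only, none or still open, it means among the compounds named here.

Compound 1 `CCCCCCCC(=O)NCC(=O)N[C@@H](C)C(=O)N[C@@H](CC(C)C)C(=O)N[C@](C)(CC)C(=O)N[C@@H](CO)C(=O)N[C@H](C(=O)N[C@H](CO)CC(C)C)[C@@H](C)CC`: 30000 nM
Compound 2 `CCCCCCCC(=O)NCC(=O)N[C@@H](C)C(=O)N[C@@H](CC(C)C)C(=O)NC(C)(C)C(=O)N[C@@H](C)C(=O)N[C@H](C(=O)N[C@H](CO)CC(C)C)[C@@H](C)CC`: 17000 nM

Both values come from a functional assay on A549 cells (Homo sapiens) for cytotoxicity, read by MTT assay, with a stated time of 48 h; on this read-out higher numbers stand for weaker inhibition and lower numbers for stronger inhibition. Compound 2 stands within the usual scatter of compound 1, so these two numbers cannot be told apart. Compound 3 `CCCCCCCC(=O)NCC(=O)N[C@@H](C)C(=O)N[C@@H](CC(C)C)C(=O)N[C@](C)(CC)C(=O)N[C@@H](C)C(=O)N[C@H](C(=O)N[C@H](CO)CC(C)C)[C@@H](C)CC` has not yet been measured. It differs from compound 2 in a single place: methyl in place of hydrogen on a saturated chain carbon, two bonds along the chain from an amide-type nitrogen and a carbonyl carbon. In words, this is methyl in place of hydrogen on a saturated chain carbon, two bonds along the chain from an amide-type nitrogen and a carbonyl carbon. Going by the values given here, no measured pair of compounds shows this change on its own, so the data offer no direct guide to its effect. For so modest a change, no step beyond the scatter is expected in this assay, in either direction. The expected step is a 1.1-fold higher number from compound 2 to compound 3 (0.02 log units; within the scatter). The estimated value for compound 3 is 18000 nM, with an expected range from 9000 nM to 35000 nM.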

Compound 3, half-maximal inhibitory concentration: 4000 nM
Compound 3: the middle estimate sits 4.5-fold (0.65 log units) above what was measured; measured number outside the range, below it.
By their numbers in this assay, from the lowest: compound 3; then compounds 2 and 1 (each within the scatter of the next).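

The methyl on this saturated chain carbon is not a silent change: in this assay it gives a 4.3-fold lower number from compound 2 to compound 3 (0.63 log units; beyond the scatter), so one added carbon at this place is enough to move the number beyond the scatter. Compound 1 and compound 2 differ in two places, so they could not show this, and compound 3 now links each of them by a single change; hydrogen in place of hydroxy gives a 7.5-fold lower number from compound 1 to compound 3 (0.88 log units; beyond the scatter). Nothing at hand explains either step.

Going by these compounds, whether a longer chain, such as propyl, at the methyl's place would lower the number further remains open. So does whether an amine in place of the hydroxy would behave like the hydroxy or like hydrogen.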